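The source may hold more compounds than are shown below. What is called first, only, known or untested is meant among the compounds shown, and "the series" means these compounds.

Of the compounds shown here, three built on a shared core have been tested in a functional assay on U-87MG ATCC cells for inhibition, with U-87 MG (Homo sapiens) as the target, read by MTT assay, with a stated time of 72 h; a higher number here means a weaker inhibitor, a lower number a stronger inhibitor. Compound 1 `Cc1noc(C)c1-c1cnc(N)c(Oc2ccc(C(=O)NC3CCCC3)cc2)n1` gives 57600 nM, compound 2 `Cc1noc(C)c1-c1cnc(N)c(Oc2ccc(C(=O)Nc3cccc(Cl)c3)cc2)n1` gives 11500 nM, and compound 3 `Cc1noc(C)c1-c1cnc(N)c(Oc2ccc(C(=O)Nc3ncccc3Cl)cc2)n1` gives 45600 nM. Compound 3 therefore stands second highest of the three numbers: it sits close to compound 1, with a 1.3-fold lower number from compound 1 to compound 3 (0.10 log units; within the scatter) falling within the scatter, while a 4.0-fold higher number from compound 2 to compound 3 (0.60 log units; beyond the scatter) lies beyond it. Among the measured compounds shown here, all the measured steps, including a 5.0-fold lower number from compound 1 to compound 2 (0.70 log units; beyond the scatter), exchange the group on the amide nitrogen and leave the rest of the molecule untouched.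

Compound 4 `Cn1cc(-c2cnc(N)c(Oc3ccc(C(=O)Nc4ncccc4Cl)cc3)n2)cn1` alters a different part of the core: 1-methyl-1H-pyrazol-4-yl in place of 3,5-dimethyl-1,2-oxazol-4-yl on an aromatic carbon. For the measured compounds named here, no measured pair shows this exchange, so none of the measured steps bears on it directly, and the data give no guide to its size or direction. In the absence of any such guide, the step is expected to be a 1.0-fold lower number from compound 3 to compound 4 (0.01 log units; within the scatter), that is, nothing beyond the scatter. Compound 4 is accordingly estimated at 45000 nM, with a range from 15000 nM to 140000 nM.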

Compound 4, half-maximal inhibitory concentration: 37600 nM
Estimate against measurement, compound 4: 1.2-fold (0.08 log units) above; low and high end bracket the measured number.
By their numbers in this assay, from the lowest: compound 2; then compounds 4, 3 and 1 (each within the scatter of the next).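

Among the compounds shown here, the earlier steps all exchanged the group on the amide nitrogen, whereas this one is the first to act at a different place, on an aromatic carbon para to an amino group. In this assay, 1-methyl-1H-pyrazol-4-yl in place of 3,5-dimethyl-1,2-oxazol-4-yl gives a 1.2-fold lower number from compound 3 to compound 4 (0.08 log units; within the scatter), so with the 3-chloropyridin-2-yl amide held fixed, one five-membered aromatic ring with 2 hetero atoms gives way to another without a step beyond the scatter. Nothing available offers an explanation for this result.

As far as these compounds go, the exchange is seen on a single amide, and whether it would read the same with the 3-chlorophenyl amide of compound 2 stays open. The compounds shown also leave open how this position responds to a phenyl ring, an amine or a carboxylic acid.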